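This account rests on a few compounds, and the source may have more. Where it says the series, first, only, none or still open, it means among the compounds named here.

In a functional assay on NB1 cells (Homo sapiens) for cytotoxicity, read by MTT assay, with a stated time of 3 days (a higher number here means a weaker inhibitor, a lower number a stronger inhibitor), three compounds built on a shared core have been measured so far. Compound 1 (`N#Cc1c(Nc2ccccn2)nc(SCc2nc3ccccc3[nH]2)nc1-c1ccccc1`) stands at 3.9 nM and compound 2 (`N#Cc1c(Nc2nccs2)nc(SCc2nc3ccccc3[nH]2)nc1-c1ccccc1`) at 3.2 nM on this scale, and the swap between them gives a 1.2-fold lower number from compound 1 to compound 2 (0.09 log units; within the scatter) and so does not separate them. Compound 3 (`N#Cc1c(NC(N)=S)nc(SCc2nc3ccccc3[nH]2)nc1-c1ccccc1`) has the highest number of the three at 11.9 nM and is the weakest of them, with a 3.1-fold higher number from compound 1 to compound 3 (0.48 log units; beyond the scatter) and a 3.7-fold higher number from compound 2 to compound 3 (0.57 log units; beyond the scatter) leading to it.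

The next change, to compound 4 (`N#Cc1c(-c2ccccc2)nc(SCc2nc3ccccc3[nH]2)nc1N1CCNCC1`), is this one (a group of 6 heavy atoms (4 carbon, 2 nitrogen; one six-membered non-aromatic ring with 2 hetero atoms) in place of a group of 4 heavy atoms (1 carbon, 2 nitrogen, 1 sulfur; no ring), on an aromatic carbon): piperazin-1-yl enters on an aromatic carbon, so a group with no ring gives way to a six-membered non-aromatic ring. Within the data shown here, all three measured steps swap a group on a nitrogen on an aromatic ring, and no measured compound carries piperazin-1-yl, so they bear on this change only loosely. They do give a sense of size, as the largest of them is a 3.7-fold higher number from compound 2 to compound 3 (0.57 log units; beyond the scatter) and still counts as modest. A step of that size could go either way here, and with no direction shown, none beyond the scatter is the best guess. The expected change is a 1.2-fold lower number from compound 3 to compound 4 (0.08 log units; within the scatter) in this assay on this reasoning. For compound 4 the estimated value is 10 nM with an expected range from 3 nM to 35 nM in this measurement.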

Compound 4, half-maximal inhibitory concentration: 6.75 nM
The estimate for compound 4 lay 1.5-fold (0.17 log units) above the measured number; the measured number falls inside the stated range.
By their numbers in this assay, from the lowest: compounds 2, 1, 4 and 3 (each within the scatter of the next, the first and the last beyond it).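

In this assay, compound 4 shows that a six-membered non-aromatic ring can sit on this aromatic carbon without a step beyond the scatter from the open-chain group (a 1.8-fold lower number from compound 3 to compound 4 (0.25 log units; within the scatter)) or from (pyridin-2-yl)amino (a 1.7-fold higher number from compound 1 to compound 4 (0.24 log units; within the scatter)). Only the comparison with (1,3-thiazol-2-yl)amino goes beyond the scatter (a 2.1-fold higher number from compound 2 to compound 4 (0.32 log units; beyond the scatter)), and that step is modest, so an aromatic ring held on a nitrogen is not needed here for a number close to those of compound 1 and compound 3. No measurement is at hand that would explain these numbers.

On these data alone, it remains open whether the piperazin-1-yl ring as a whole matters or only part of it, which morpholin-4-yl or piperidin-1-yl on the same aromatic carbon, or an open-chain amine such as dimethylamino, could help to settle. A methyl or acetyl group on the second nitrogen of piperazin-1-yl would also show whether that ring atom can carry more without a larger step.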